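Replacing a Dihydroxyphenyl Group with a Dimethylphenyl Group

A few compounds are considered here, and "the series" means these few. Any claim that something is new, unique, unknown or untested is made for them only; others in the source may bear on it.

In a functional assay on DU-145 cells (Homo sapiens) for inhibition, read by trypan blue exclusion, with a stated time of 96 h (on this read-out higher numbers stand for weaker inhibition of growth and lower numbers for stronger inhibition of growth), compound 1 (`O=C(/C(=C\c1ccc(O)cc1O)Sc1ccc(Br)cc1)c1ccc(Cl)cc1`) gives 50000 nM. Two relatives provide the comparison: compound 2 (`Cc1cc(C)cc(/C=C(/SCc2ccc(F)cc2)C(=O)c2ccc(Br)cc2)c1`) gives 10000 nM, and compound 3 (`COc1ccccc1/C=C(/SCc1ccc(F)cc1)C(=O)c1ccc(Br)cc1`) gives 10000 nM. Compound 1 therefore has the highest number of the three, and its gap to each of the others lies beyond the usual scatter of repeated measurements.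

Compound 4 (`Cc1ccc(C)c(/C=C(/Sc2ccc(Br)cc2)C(=O)c2ccc(Cl)cc2)c1`) differs from compound 1 in a single group: 2,5-dimethylphenyl in place of 2,4-dihydroxyphenyl on a double-bonded chain carbon bound to a double-bonded chain carbon. Put simply, 2,5-dimethylphenyl takes the place of 2,4-dihydroxyphenyl on a double-bonded chain carbon bound to a double-bonded chain carbon.

Among the measured compounds shown here, only one measured step involves this place: no change at the digits printed from compound 2 to compound 3 (within the scatter). That step offers little guidance on size, and compound 2 and compound 3 also differ from compound 1 elsewhere, so no measurement isolates the present swap. The best available hint is compound 2, which also has a dimethyl-substituted phenyl group at this place and gives 10000 nM. A moderate fall in the number, meaning stronger inhibition of growth, is therefore expected in this assay. The expected step is a 4.2-fold lower number from compound 1 to compound 4 (0.62 log units; beyond the scatter), though this remains uncertain. For compound 4, the estimated value is 12000 nM, with an expected range from 3000 nM to 50000 nM.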

Compound 4, concentration for 50% growth inhibition: 10000 nM
The estimate for compound 4 lay 1.2-fold (0.08 log units) above the measured number; low and high end bracket the measured number.
By their numbers in this assay, from the lowest: compounds 2, 3 and 4 (each within the scatter of the next); then compound 1.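

In this assay, among the compounds shown here, the change from 2,4-dihydroxyphenyl to 2,5-dimethylphenyl gives a 5.0-fold lower number from compound 1 to compound 4 (0.70 log units; beyond the scatter), and this is the first direct reading of that swap with the rest of compound 1 left unchanged. For the compounds shown here, the only earlier step at this place showed no change at the digits printed from compound 2 to compound 3 (within the scatter), so the result adds something new: the group on a double-bonded chain carbon bound to a double-bonded chain carbon can shift the number beyond the scatter. The group that leaves has 2 hydrogen-bond donors and 2 hydrogen-bond acceptors, while the group that enters has 0 of each at the same 8 heavy atoms, but no measurement here explains the step.

Going by these compounds, both hydroxy groups were replaced and the substitution pattern changed in the same step, so it remains open whether the shift follows from losing the hydroxy groups, gaining the methyl groups or moving the substituents, which a phenyl group carrying a single hydroxy or methyl group could help separate. On these data alone, it is also open how this place would respond to a phenyl group carrying an amine or a carboxylic acid, and whether the same swap would behave alike in the fluorobenzyl-sulfur series of compound 2 and compound 3.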